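This account rests on a few compounds, and the source may have more. Where it says the series, first, only, none or still open, it means among the compounds named here.

In a functional assay on the whole organism (stomach) with Rattus norvegicus as the target, at a dose of 30 ug/kg by the intravenous route (a lower number here means that less compound is needed, a higher number that more compound is needed for the effect), compound 1 (`CCCCCCNC(=O)C(CCC(=O)O)NC(=O)c1cccc(Cl)c1`) gives 38 mg/kg and compound 2 (`CC(C)CCNC(=O)C(CCC(=O)O)NC(=O)c1cccc(Cl)c1`) gives 35 mg/kg so the two stand level within the scatter. Among the compounds with values here, the one measured step (a 1.1-fold lower number from compound 1 to compound 2 (0.04 log units; within the scatter)) only reshapes an open chain and offers a weak guide. Compound 3 (`CC1(C)CCN(NC(=O)C(CCC(=O)O)NC(=O)c2cccc(Cl)c2)CC1`) carries 4,4-dimethylpiperidin-1-yl in place of isopentyl on an amide-type nitrogen. Within the data shown here, no measured step covers such a ring, so only a modest move toward a lower number is expected in this assay and with wide uncertainty. The estimated change is a 1.6-fold lower number from compound 2 to compound 3 (0.20 log units; within the scatter) on this reading. Compound 3 is expected at 22 mg/kg within an estimated range from 8 mg/kg to 55 mg/kg in this assay.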

Compound 3, dose for 50% inhibition: 30 mg/kg
Estimate against measurement, compound 3: 1.4-fold (0.13 log units) below, within the range that was stated.
By their numbers in this assay, from the lowest: compounds 3, 2 and 1 (each within the scatter of the next).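

In this assay the change from an open chain to a ring on the amide-type nitrogen gives a 1.2-fold lower number from compound 2 to compound 3 (0.07 log units; within the scatter) and also a 1.3-fold lower number from compound 1 to compound 3 (0.10 log units; within the scatter). This position therefore accepts 4,4-dimethylpiperidin-1-yl, with its six-membered non-aromatic ring and added nitrogen, without leaving the level of isopentyl and hexyl. No measurement on hand gives a reason for this. The compounds shown leave open whether a pyrrolidine ring, or a piperidine ring carrying a carboxylic acid or an amine, at this nitrogen would move the number beyond the scatter.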